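Compound 3 against compound 2: thiophen-3-yl for pyridin-3-yl

This account rests on a few compounds, and the source may have more. Where it says the series, first, only, none or still open, it means among the compounds named here.

Compound 1 `Oc1ccc(-c2cc(-c3ccncc3)nc(-c3ccc(Cl)cc3)c2)cc1` shows "not determined" (no result reported) in a functional assay on HCT-15 cells (Homo sapiens) for cytotoxicity, read by CCK-8 assay and cell counting, with a stated time of 2 days; on this read-out lower numbers stand for stronger inhibition and higher numbers for weaker inhibition. Going by the values given here, compound 2 `Oc1ccc(-c2cc(-c3ccc(Cl)cc3)nc(-c3cccnc3)c2)cc1` gives 20700 nM in this assay, the only number the series shows so far, so it stands alone without a measured neighbour to compare. Compound 3 `Oc1ccc(-c2cc(-c3ccc(Cl)cc3)nc(-c3ccsc3)c2)cc1` differs from compound 2 by thiophen-3-yl in place of pyridin-3-yl on an aromatic carbon. Among the compounds with values here, no measured step exists for this kind of exchange. The step of a 1.2-fold lower number from compound 2 to compound 3 (0.06 log units; within the scatter) is expected to stay within the usual scatter, with no clear direction either way. Compound 3 is therefore estimated at 18000 nM, with a range from 7000 nM to 50000 nM in this assay.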

Compound 3, half-maximal inhibitory concentration: 6240 nM
The estimate for compound 3 lay 2.9-fold (0.46 log units) above the measured number; the whole stated range lies above it.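

In this assay, going by these compounds alone, thiophen-3-yl in place of pyridin-3-yl next to the ring nitrogen gives a 3.3-fold lower number from compound 2 to compound 3 (0.52 log units; beyond the scatter), the first step and one beyond the scatter. This position therefore responds to the identity of the attached aromatic ring, although the step alone does not separate ring size from the change of hetero atom. No measurement at hand accounts for the step.

Still open, from the compounds shown here alone, is how an unsubstituted phenyl, an amine or a carboxylic acid at this position would compare. Also open, going by these compounds, is whether the step holds when the 4-chlorophenyl or 4-hydroxyphenyl group is changed.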